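Compound 3 and the swap from chloro to methyl

A few compounds are considered here, and "the series" means these few. Any claim that something is new, unique, unknown or untested is made for them only; others in the source may bear on it.

Measured so far in a physicochemical assay for lipophilicity (a lower number here means a more polar compound, a higher number a more lipophilic compound), for three compounds:
- compound 1 `Cc1ccc(/C=C2\CCC/C(=C\c3ccccc3[N+](=O)[O-])C2=O)cc1` with 5.15
- compound 2 `O=C1/C(=C/c2ccccc2)CCC/C1=C\c1cccc([N+](=O)[O-])c1` with 4.9
- compound 3 `O=C1/C(=C/c2ccc(Cl)cc2)CCC/C1=C\c1ccc([N+](=O)[O-])cc1` with 5.6

Compound 3 holds the highest of the three numbers, and its gaps down to compound 1 and to compound 2 both lie beyond the scatter, the gap to compound 2 being the wider.

Compound 4 `Cc1ccc(/C=C2\CCC/C(=C\c3ccc([N+](=O)[O-])cc3)C2=O)cc1` differs from compound 3 at a single place (methyl in place of chloro on an aromatic carbon): methyl in place of chloro on an aromatic carbon, para to a large group, so that 4-chlorophenyl becomes 4-methylphenyl.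

Among the compounds with values here, no pair of measured compounds differs in one place only, so this step has no direct precedent in the data. The nearest hint is compound 1, which also bears 4-methylphenyl and gives 5.15 in this assay but differs from compound 3 elsewhere as well. That makes it a loose guide, pointing downward only. A small fall is therefore expected, and an estimated a number 0.20 log units lower from compound 3 to compound 4 (within the scatter) would stay within the scatter. The expected value for compound 4 is 5.4 with an estimated range from 5.1 to 5.7 on this reading.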

Compound 4, partition coefficient: 5.38
Compound 4: middle estimate off by 0.02 log units, on the high side; measured number inside the range.
By their numbers in this assay, from the lowest: compounds 2, 1, 4 and 3 (each within the scatter of the next, the first and the last beyond it).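

In this assay, methyl in place of chloro on an aromatic carbon, para to a large group, gives a number 0.22 log units lower from compound 3 to compound 4 (within the scatter). Within the data shown here, this is the first step in the set in which only one place differs, so the change from 4-chlorophenyl to 4-methylphenyl can now be read directly, with the rest of compound 3 left as it stands, and the two groups cannot be told apart at this position by this read-out. That reading rests on a single pair on a single background, and no measurement shown here offers an explanation for the step.

The compounds shown leave open whether the same exchange would stay within the scatter on another background, such as the core of compound 1 or compound 2, since a second matched pair would be needed to tell whether the result carries beyond this one. They also leave open how far the number at this position can move with groups of another kind, such as an amine, a carboxylic acid, a methoxy group or a longer chain such as butyl in place of chloro or methyl.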